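This account rests on a few compounds, and the source may have more. Where it says the series, first, only, none or still open, it means among the compounds named here.

Working notes on the series, all on the shared core. In an ADME assay on Vero cells (Chlorocebus sabaeus) for cytotoxicity, read by MTT assay, with a stated time of 72 h (on this read-out lower numbers stand for an effect already at smaller amounts and higher numbers for an effect only at larger amounts of compound), compound 1 (`COc1ccc(C(=O)Nc2nc(-c3ccccn3)cs2)cc1`) gives 9200 nM and compound 2 (`CC(=O)c1ccc(C(=O)Nc2nc(-c3ccccn3)cs2)cc1`) gives 10500 nM with acetyl in place of methoxy, which is a 1.1-fold higher number from compound 1 to compound 2 (0.06 log units; within the scatter) and separates little. Compound 3 (`O=C(Nc1nc(-c2ccccn2)cs1)c1ccc(Br)cc1`) gives 4700 nM with bromo on the same aromatic carbon. Bromo in place of methoxy is a 2.0-fold lower number from compound 1 to compound 3 (0.29 log units; within the scatter) while bromo in place of acetyl is a 2.2-fold lower number from compound 2 to compound 3 (0.35 log units; beyond the scatter) and so compound 3 stands apart from compound 2 only.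

Compound 4 (`O=C(Nc1nc(-c2ccccn2)cs1)c1cccnc1Cl`) has 2-chloropyridin-3-yl in place of 4-bromophenyl on a carbonyl carbon. Among the compounds with values here, no measured step replaces a whole aromatic group, so the evidence is indirect. Within the data shown here, the only steps involving the bromo group are those into compound 3, and the larger of them, a 2.2-fold lower number from compound 2 to compound 3 (0.35 log units; beyond the scatter) is still small. Removing the bromo group is therefore expected to give a small move toward higher numbers in this assay near the edge of the scatter, with real uncertainty. The estimated step is a 1.8-fold higher number from compound 3 to compound 4 (0.26 log units; within the scatter) and a step of opposite sign cannot be excluded. For compound 4 the estimated value is 8500 nM (expected range 3800 nM to 19000 nM).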

Compound 4, half-maximal effective concentration: 1900 nM
Compound 4: middle estimate off by 4.5-fold (0.65 log units), on the high side; the whole stated range lies above it.
By their numbers in this assay, from the lowest: compound 4; then compounds 3, 1 and 2 (each within the scatter of the next, the first and the last beyond it).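

The position on the carbonyl carbon accepts more than a change of substituent: with the whole aromatic group exchanged, 2-chloropyridin-3-yl in place of 4-bromophenyl, this assay shows a 2.5-fold lower number from compound 3 to compound 4 (0.39 log units; beyond the scatter). The earlier steps shown here only exchanged methoxy, acetyl and bromo on one aromatic carbon of an otherwise unchanged ring, whereas this step alters the ring itself, and with it the halogen, and still moves beyond the scatter, though only modestly. Nothing shown here accounts for the direction or size of this step.

On these data alone, the step combines several changes at once: bromo leaves, chloro enters, and a ring carbon gives way to a ring nitrogen, so the share of each in the lower number stays open, and a phenyl ring carrying chloro alone or a pyridine ring without chloro would be needed to separate them. Also open is how the same read-out responds to an amine or a carboxylic acid on this aromatic group, since the compounds shown carry only methoxy, acetyl and halogen substituents there.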